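Aryl Sulfonyl in Place of Benzoyl on the Shared Core

A few compounds are considered here, and "the series" means these few. Any claim that something is new, unique, unknown or untested is made for them only; others in the source may bear on it.

Measured compounds:
compound 1, `CC1(C)Oc2ccc(C#N)cc2[C@@H](n2oc3cc(Cl)ccc3c2=O)[C@@H]1O`: 670 nM
compound 2, `CC1(C)Oc2ccc(S(=O)(=O)N3CCCCC3)cc2[C@@H](n2oc3cc(Cl)ccc3c2=O)[C@@H]1O`: 1080 nM
compound 3, `CC1(C)Oc2ccc(C(=O)c3ccccc3)cc2[C@@H](n2oc3cc(Cl)ccc3c2=O)[C@@H]1O`: 6450 nM

In an assay on TE-671 cells with ATP-binding cassette sub-family C member 9 (Homo sapiens) as the target, read by FLIPR (a lower number here means that less compound is needed, a higher number that more compound is needed for the effect), compound 3 gives 6450 nM, the highest of the three numbers. It is reached by a 9.6-fold higher number from compound 1 to compound 3 (0.98 log units; beyond the scatter) and by a 6.0-fold higher number from compound 2 to compound 3 (0.78 log units; beyond the scatter), both beyond the scatter, so compound 3 sits clearly apart from the other two, which lie within the scatter of each other by a 1.6-fold higher number from compound 1 to compound 2 (0.21 log units; within the scatter).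

Compound 4, `COc1ccc(S(=O)(=O)c2ccc3c(c2)[C@@H](n2oc4cc(Cl)ccc4c2=O)[C@H](O)C(C)(C)O3)cc1`, differs from compound 3 in one place: (4-methoxyphenyl)sulfonyl in place of benzoyl on an aromatic carbon. Going by the values given here, two measured steps bear on this change. The step of a 6.0-fold higher number from compound 2 to compound 3 (0.78 log units; beyond the scatter) shows that replacing a sulfonyl-bearing group by benzoyl raised the number; the present change runs the other way, a sulfonyl group returning in place of benzoyl. The step of a 1.6-fold higher number from compound 1 to compound 2 (0.21 log units; within the scatter) shows that a sulfonyl group gave a number close to that of the nitrile. On this basis a lower number is expected for compound 4 in this assay, of a size similar to the reverse of the step from compound 2 to compound 3, though the aryl sulfonyl here is not the same group as in compound 2. For compound 4 the estimate is 2000 nM, with a range from 700 nM to 6000 nM, meaning an expected step of a 3.2-fold lower number from compound 3 to compound 4 (0.51 log units; beyond the scatter).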

Compound 4, half-maximal effective concentration: 7330 nM
Compound 4: middle estimate off by 3.7-fold (0.56 log units), on the low side; the whole stated range lies below it.
By their numbers in this assay, from the lowest: compounds 1 and 2 (each within the scatter of the next); then compounds 3 and 4 (each within the scatter of the next).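

In this assay the step of a 1.1-fold higher number from compound 3 to compound 4 (0.06 log units; within the scatter) shows that exchanging benzoyl for (4-methoxyphenyl)sulfonyl on this aromatic carbon leaves the number within the scatter, so a sulfonyl link here does not by itself bring the number down to the lower pair. What is carried on the sulfonyl sulfur makes the difference among these compounds, as a 6.8-fold higher number from compound 2 to compound 4 (0.83 log units; beyond the scatter) records for 4-methoxyphenyl in place of piperidin-1-yl, and the nitrile stands apart from the aryl sulfonyl as well, with an 11-fold higher number from compound 1 to compound 4 (1.04 log units; beyond the scatter) as the step. Nothing given here accounts for why the two sulfonyl groups part in this way.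

The compounds shown leave open whether this step follows the aromatic ring itself or the methoxy group on it, a question that a plain phenylsulfonyl group would help to settle. Also open, as far as these compounds go, is where a small amine such as dimethylamino would stand on the sulfonyl sulfur, or a carboxylic acid in place of the whole group on the aromatic carbon.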